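The source may report more compounds than this note shows. Statements on the series, on what has been measured and on what is new or still open speak of the compounds shown alone.

Three close relatives, compound 1 `CC1(C)CC(NC(=O)Nc2ccccc2Cl)c2cc(F)ccc2O1`, compound 2 `CC1(C)CC(NC(=O)Nc2ccccc2Cl)c2cc(Cl)ccc2O1` and compound 3 `CC1(C)CC(NC(=O)Nc2ccccc2Cl)c2cc(Br)ccc2O1`, have been tested in a functional assay on U-373MG ATCC cells (Homo sapiens) for inhibition, read by MTT assay, with a stated time of 72 h; a lower number here means a stronger inhibitor, a higher number a weaker inhibitor. They differ only in one halogen on an aromatic carbon: fluoro, chloro or bromo. Compound 1 gives 40000 nM, compound 2 gives 17000 nM and compound 3 gives 19000 nM. Compound 2 stands level with compound 3, as a 1.1-fold higher number from compound 2 to compound 3 (0.05 log units; within the scatter) lies within the scatter. Both sit at the low end of these three numbers, and compound 1 is clearly weaker, with a 2.4-fold lower number from compound 1 to compound 2 (0.37 log units; beyond the scatter) and a 2.1-fold lower number from compound 1 to compound 3 (0.32 log units; beyond the scatter).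

Compound 4 `CCNC(=O)NC1CC(C)(C)Oc2ccc(Cl)cc21` keeps the chloro but changes a different part of compound 2: ethyl in place of 2-chlorophenyl on an amide-type nitrogen. Among the measured compounds shown here, no measured step touches that place, so the halogen steps bear on it only indirectly. They are modest and show how far a single-atom swap moved the number here. Losing a whole aromatic ring is a much larger structural change, so a larger step is expected, probably towards a higher number and a weaker inhibitor, although the data cannot confirm this direction. The estimated step is a 3.5-fold higher number from compound 2 to compound 4 (0.55 log units; beyond the scatter). For compound 4 the expected value is 60000 nM, within an estimated range of 20000 nM to 200000 nM.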

Compound 4, half-maximal inhibitory concentration: > 100000 nM
Compound 4 gave a limit, no number; the forecaster's own chance of this, stated with the estimate: 30%; middle value at least 1.6-fold (0.22 log units) from the limit.
By their numbers in this assay, from the lowest: compounds 2 and 3 (each within the scatter of the next); then compound 1. At a limit, above all of these: compound 4.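

In this assay compound 4 gives > 100000 nM, which is a limit and not a number. Until now, every change had been a single halogen on the aromatic ring of the shared core, and the largest such step was modest: a 2.4-fold lower number from compound 1 to compound 2 (0.37 log units; beyond the scatter). Putting ethyl in place of 2-chlorophenyl on the amide-type nitrogen gives a clearly larger step, an at least 5.8-fold higher number from compound 2 to compound 4 (0.76 log units; beyond the scatter), so the group at this place can shift the number further than any halogen swap shown, and in the direction of a weaker inhibitor. Its true size remains unknown, since the step gives only a lower bound on the change: the limit of > 100000 nM in this assay, at which 1 of the 4 values shown sits.

The compounds shown cannot tell whether the loss follows from removing the aromatic ring, the chlorine on it or simply the larger group, as all of these leave together in this one change. A plain phenyl group would separate the ring from its chlorine, while a longer chain such as butyl or a saturated ring such as cyclohexyl would show whether a larger group without an aromatic ring can restore the number.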